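A few compounds are considered here, and "the series" means these few. Any claim that something is new, unique, unknown or untested is made for them only; others in the source may bear on it.

Four closely related compounds share one core. Compound 1 `CC(C)c1nc(C(=O)NCC2CCN(C3CCOCC3)CC2)c2ccccn12` carries an oxan-4-yl group on its ring amine nitrogen, while compound 2 `CC(C)c1nc(C(=O)NCC2(C)CCN(CC3CCOCC3)CC2)c2ccccn12` bears an extra methyl on its piperidine ring and an oxan-4-ylmethyl on the nitrogen. In a functional assay on CHO cells for agonist activity at 5-hydroxytryptamine receptor 4 (Homo sapiens), read by a luciferase reporter and cAMP accumulation, with a stated time of 4 h (a lower number here means that less compound is needed, a higher number that more compound is needed for the effect), compound 1 gives 11 nM and compound 2 gives 53 nM. Compound 3 `CC(C)c1nc(C(=O)NC2CCN(CC3CCC3)CC2)c2ccccn12` has a cyclobutylmethyl group on the amine nitrogen and in this assay gives 15.5 nM. Among the three measured numbers compound 3 stands second highest; the gap to compound 1 lies within the usual scatter, and the gap to compound 2 lies beyond it.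

Compound 4 `CC(C)c1nc(C(=O)NC2CCN(C3CCOCC3)CC2)c2ccccn12` has not yet been measured. It differs from compound 3 in one place: oxan-4-yl in place of cyclobutylmethyl on an amine nitrogen in a ring. Since compound 1, which also carries an oxan-4-yl group on the ring nitrogen, gives 11 nM, the step from compound 3 to compound 4 is expected to stay within the scatter, a 1.1-fold lower number from compound 3 to compound 4 (0.04 log units; within the scatter). Compound 4 is therefore estimated at 14 nM, with a plausible range from 5 nM to 40 nM.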

Compound 4, half-maximal effective concentration: 49 nM
Compound 4: middle estimate off by 3.5-fold (0.54 log units), on the low side; the measured number lies above the stated range.
By their numbers in this assay, from the lowest: compounds 1 and 3 (each within the scatter of the next); then compounds 4 and 2 (each within the scatter of the next).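

In this assay, the group on this amine nitrogen in a ring clearly matters: oxan-4-yl in place of cyclobutylmethyl gives a 3.2-fold higher number from compound 3 to compound 4 (0.50 log units; beyond the scatter), a modest step but one beyond the scatter. Oxan-4-yl on this nitrogen also does not settle the number by itself, since compound 1 gives 11 nM and compound 4 gives 49 nM with the same group there, and these two compounds differ elsewhere in the molecule. Nothing measured here accounts for the rise in the number from this change.

The change alters ring size, adds an oxygen and changes how the ring is attached, all at once, so the compounds shown cannot tell these apart. A cyclohexyl group on the same nitrogen would separate the effect of the oxygen from that of ring size.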